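Carbamate selenocyanates: methyl for fluoro on the aryl carbamate

The compounds below may be only part of what the source reports. "The series", "measured", "known", "first", "only" and "open" are said of these compounds alone.

The series shares a carbamate bearing a selenocyanate-substituted aniline. Compound 1 `COc1ccc(OC(=O)Nc2ccc([Se]C#N)cc2)cc1` gives 70000 nM in a functional assay on CCRF-CEM cells (Homo sapiens) for cytotoxicity, read by MTT assay, with a stated time of 72 h; on this read-out lower numbers stand for higher toxicity in this test and higher numbers for lower toxicity in this test. Compound 2 `CCOC(=O)Nc1ccc([Se][Se]c2ccc(NC(=O)OCC)cc2)cc1`, the diselenide with ethyl carbamates, gives 74300 nM in this assay. Compound 3 `N#C[Se]c1ccc(NC(=O)Oc2ccc(F)cc2)cc1` gives 71100 nM in this assay. Compound 3 stands second highest of the three numbers; its nearest neighbour is compound 1 and its furthest is compound 2, and both gaps lie within the scatter. Going by the values given here, the single counted step, a 1.0-fold higher number from compound 1 to compound 3 (0.01 log units; within the scatter), is also within the scatter.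

The next member, compound 4 `Cc1ccc(OC(=O)Nc2ccc([Se]C#N)cc2)cc1`, differs from compound 3 by methyl in place of fluoro on an aromatic carbon.

Among the compounds with values here, the only measured step at this position is the one from compound 1 to compound 3, and it moved the number by nothing beyond the scatter. Within the data shown here, no measured pair carries a methyl at this position, so the direct bearing of the change is untested; the closest analogy is that one change of the group on this ring left the read-out unmoved. Compound 4 is therefore expected to show a 1.0-fold lower number from compound 3 to compound 4 (0.00 log units; within the scatter), a step of no consequence beyond the scatter, in this assay. The estimated value for compound 4 is 71000 nM, with a range from 35000 nM to 145000 nM.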

Compound 4, concentration lethal to 50% of the cells: 72000 nM
For compound 4 the middle estimate is 1.0-fold (0.01 log units) below the measured one; the range from low to high includes it.
By their numbers in this assay, from the lowest: compounds 1, 3, 4 and 2 (each within the scatter of the next).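

With methyl now measured on an aromatic carbon para to a large group, three groups at this place can be compared in this assay: the change of fluoro to methyl gives a 1.0-fold higher number from compound 3 to compound 4 (0.01 log units; within the scatter) and the change of methoxy to methyl gives a 1.0-fold higher number from compound 1 to compound 4 (0.01 log units; within the scatter). Where the earlier compounds offered a single unmoved swap, fluoro, methoxy and methyl now form a set of three that this test does not tell apart, and methyl, the first simple carbon group at this place, falls in with the other two. The data on hand offer no explanation for this flat read-out.

On these data alone, whether a group of another kind at this place, such as an amine, a carboxylic acid or a longer chain, would move the number beyond the scatter remains open. Also open, as far as these compounds go, is whether the same flat response would hold with the selenocyanate replaced, since compound 2, the only diselenide here, differs from the other compounds in more than one place and gives no clean comparison.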